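The source may report more compounds than this note shows. Statements on the series, on what has been measured and on what is new or still open speak of the compounds shown alone.

Two compounds stand measured in an in vitro ADME assay on microsomes from liver (Homo sapiens) for metabolic stability, tested at 5 uM (a lower number here means that the compound disappears faster, a higher number that the compound lasts longer), so far:

Compound 1 (`CCC(C)(C)Cn1nc(-c2cccs2)c(O)c(C2=NS(=O)(=O)c3cc(NS(C)(=O)=O)ccc3N2)c1=O`) gives > 1 h as a limit.
Compound 2 (`CS(=O)(=O)Nc1ccc2c(c1)S(=O)(=O)N=C(c1c(O)c(-c3cccs3)nn(CCC3CCCC3)c1=O)N2`) gives > 1 h as a limit.

The evidence so far is the limit of > 1 h in this assay, at which 2 of the 2 values shown sit, and nothing more. Compound 2 therefore stands only at a limit, with no number. Compound 3 (`CS(=O)(=O)Nc1ccc2c(c1)S(=O)(=O)N=C(c1c(O)c(-c3cccs3)nn(CCC3CCCCC3)c1=O)N2`) carries cyclohexyl in place of cyclopentyl on a saturated chain carbon, two bonds along the chain from an aromatic nitrogen. Within the data shown here, the one measured step is a step that the two limits leave unreadable from compound 1 to compound 2 and it also alters this chain, but it offers no size to carry over. In this assay no step beyond the scatter is therefore expected, in either direction. The expected step is a step that the limit leaves unreadable from compound 2 to compound 3 in size. Compound 3 is expected at 1.5 h with 0.8 h to 4 h as the estimated range.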

Compound 3, half-life: > 1 h
Compound 3 ended at the assay's limit; the forecaster's own chance of this, stated with the estimate: 80%; the middle value lies beyond the limit too.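

Among these compounds, compound 1, compound 2 and compound 3 all sit at a limit in this assay, so no step among them can be read. The compounds shown leave open how long each one actually lasts and whether changing the chain alters that: the limit of > 1 h in this assay, at which 3 of the 3 values shown sit.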